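Swapping bromo for chloro on a quinoline-linked isatin core

The source may hold more compounds than are shown below. What is called first, only, known or untested is meant among the compounds shown, and "the series" means these compounds.

Measured compounds:
compound 1 `O=C1C(=O)N(CN2CCN(c3ccnc4cc(Cl)ccc34)CC2)c2cccc(Cl)c21` gives 39100 nM
compound 2 `O=C1C(=O)N(CN2CCN(c3ccnc4cc(Cl)ccc34)CC2)c2cccc(Br)c21` gives 15100 nM
compound 3 `NC(=S)N/N=C1/C(=O)N(CN2CCN(c3ccnc4cc(C(F)(F)F)ccc34)CC2)c2cc(Cl)ccc21` gives 24600 nM

These three compounds were tested in a functional assay on MCF7 cells (Homo sapiens) for cytotoxicity, read by sulforhodamine B assay, with a stated time of 48 h; a lower number here means a stronger inhibitor of growth, a higher number a weaker inhibitor of growth. Compound 1 and compound 2 share one core and differ in a single place: bromo in place of chloro on an aromatic carbon This gave a 2.6-fold lower number from compound 1 to compound 2 (0.41 log units; beyond the scatter).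

Compound 3 is built on a different core; the difference between the two cores is not broken down here. In this assay compound 3 sits close to compound 1, and the gap between them lies within the usual scatter, so no order between the two can be read from it.

Compound 4 `NC(=S)N/N=C1/C(=O)N(CN2CCN(c3ccnc4cc(C(F)(F)F)ccc34)CC2)c2cc(Br)ccc21` has not yet been measured. It relates to compound 3 in the same kind of change as compound 2 to compound 1: bromo in place of chloro on an aromatic carbon The surroundings of the place are not identical, though: in compound 1 the aromatic carbon is ortho to a fused ring and meta to a fused ring, whereas in compound 3 it is meta to a fused ring and para to a fused ring.

Only one earlier example of this kind of change exists among these compounds, so the expectation rests on a single step. Among the compounds with values here, compound 4 is expected to show a 2.2-fold lower number from compound 3 to compound 4 (0.35 log units; beyond the scatter) in this assay, a step of similar size and direction to the one seen between compound 1 and compound 2. The estimate for compound 4 in this assay is 11000 nM, with a plausible range from 5000 nM to 30000 nM.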

Compound 4, concentration for 50% growth inhibition: 35500 nM
The estimate for compound 4 lay 3.2-fold (0.51 log units) below the measured number; the measured number lies above the stated range.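

In this assay, the swap of bromo for chloro on an aromatic carbon of the second core brings a 1.4-fold higher number from compound 3 to compound 4 (0.16 log units; within the scatter), so no real change can be read from it on this core. Set beside the earlier step, the same swap did not carry over from one core to the other: the same change on two cores in this assay, a 2.6-fold lower number (0.41 log units; beyond the scatter) from compound 1 to compound 2 and a 1.4-fold higher number (0.16 log units; within the scatter) from compound 3 to compound 4, 3.7-fold (0.57 log units) apart, beyond the scatter of two such steps. Within the data shown here, this shows that a gain seen on one core cannot simply be transferred to another, but with only one step on each core it does not show which difference between the cores matters, as the place of the swap and the rest of the molecule both differ.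

The compounds shown carry only chloro or bromo at this place, so it remains open how a fluoro group, a methoxy group or an amine there would behave on either core. From the compounds shown here alone, it also remains open whether moving the halogen to the other place on a single core would alter the step, a comparison that would separate the effect of the place from that of the rest of the core.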